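Methylsulfanyl in place of isopropoxy: an estimate for compound 4

The compounds below may be only part of what the source reports. "The series", "measured", "known", "first", "only" and "open" are said of these compounds alone.

Of the compounds shown here, three built on a shared core have been measured in a functional assay on HeLa cells (Homo sapiens) for antiproliferative activity, read by MTT assay, with a stated time of 72 h; a lower number here means a stronger inhibitor, a higher number a weaker inhibitor. Compound 1, `COc1cc(-n2ncnc2-c2cccc([N+](=O)[O-])c2)cc(OC)c1OC`, reaches only the limit of this assay and gives > 10000 nM. Compound 3, `COc1cc(-c2ncnn2-c2cccc([N+](=O)[O-])c2)cc(OC)c1OC`, likewise stops at the limit and gives > 10000 nM. Going by the values given here, compound 2, `COc1cc(-n2ncnc2-c2ccc(OC(C)C)cc2)cc(OC)c1OC`, is the single compound with a number: in this assay compound 2 gives 600 nM. It therefore stands alone, with the other two values sitting at the limit of > 10000 nM in this assay, at which 2 of the 3 values shown sit.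

Compound 4, `COc1cc(-n2ncnc2-c2ccc(SC)cc2)cc(OC)c1OC`, has not yet been measured. It differs from compound 2 in one place: methylsulfanyl in place of isopropoxy on an aromatic carbon. No step between two measured compounds that differ in a single place is shown, so the size of the change is not anchored by a comparable measured pair. Among the compounds with values here, since compound 2 is the only compound with a number in this assay, compound 4 is expected to sit near it, with a modest shift of a 1.3-fold lower number from compound 2 to compound 4 (0.12 log units; within the scatter) that may well fall within the scatter. Compound 4 is estimated at 450 nM, ranging from 100 nM to 3000 nM.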

Compound 4, half-maximal inhibitory concentration: 150 nM
The estimate for compound 4 lay 3.0-fold (0.48 log units) above the measured number; low and high end bracket the measured number.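

Replacing isopropoxy with methylsulfanyl on the aromatic carbon para to a large group gives a 4.0-fold lower number from compound 2 to compound 4 (0.60 log units; beyond the scatter) in this assay. Going by these compounds alone, this is the first measured step at this position, and it shows that the read-out responds to a change there, whereas compound 2 alone could show no such response. Nothing shown accounts for the size of this step.

As far as these compounds go, compound 1 and compound 3 still give only a limit and offer no number to compare: the limit of > 10000 nM in this assay, at which 2 of the 4 values shown sit. Also open is whether the step follows the sulfur or the shorter group, which a methoxy or an ethylsulfanyl group at the same place could separate, and how an amine or a carboxylic acid there would read in this assay.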